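The source may report more compounds than this note shows. Statements on the series, on what has been measured and on what is new or still open speak of the compounds shown alone.

Three compounds built on the shared core of compound 1 `COc1ccc(C(=O)c2cc(OC)c(OC)c(OC)c2)cc1N` were tested in a functional assay on HeLa cells (Homo sapiens) for cytotoxicity, read by MTT assay, with a stated time of 72 h; a lower number here means a stronger inhibitor, a higher number a weaker inhibitor. Compound 1 gives 60 nM, compound 2 `COc1ccc(C(=O)c2cc(OC)c(OC)c(OC)c2)cc1NC(=O)/C=C/c1cc(OC)c(OC)c(OC)c1` gives 1500 nM, and compound 3 `C#CCOc1cccc(/C=C/C(=O)Nc2cc(C(=O)c3cc(OC)c(OC)c(OC)c3)ccc2OC)c1` gives 14000 nM, the highest of the three numbers. Within the data shown here, the one measured step that bears on the change is a 9.3-fold higher number from compound 2 to compound 3 (0.97 log units; beyond the scatter). Compound 4 `COc1ccc(C(=O)c2cc(OC)c(OC)c(OC)c2)cc1NC(=O)/C=C/c1ccc(F)c(F)c1` differs from compound 3 by 3,4-difluorophenyl in place of 3-(propargyloxy)phenyl on a double-bonded chain carbon bound to a double-bonded chain carbon. Among the measured compounds shown here, no measured step puts fluorine at this place, so that step shows only that the group here can move the number strongly. A modest fall is expected, a 2.3-fold lower number from compound 3 to compound 4 (0.37 log units; beyond the scatter). Compound 4 is therefore estimated at 6000 nM, with a range from 1500 nM to 25000 nM.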

Compound 4, half-maximal inhibitory concentration: 8100 nM
Estimate against measurement, compound 4: 1.4-fold (0.13 log units) below, within the range that was stated.
By their numbers in this assay, from the lowest: compound 1; then compound 2; then compounds 4 and 3 (each within the scatter of the next).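

In this assay, 3,4-difluorophenyl and 3-(propargyloxy)phenyl cannot be told apart at this place on the chain (a 1.7-fold lower number from compound 3 to compound 4 (0.24 log units; within the scatter)). Compared with 3,4,5-trimethoxyphenyl, the 3,4-difluorophenyl group gives a clearly weaker compound (a 5.4-fold higher number from compound 2 to compound 4 (0.73 log units; beyond the scatter)), so compound 2 now keeps the lower number against both other groups tested here. Nothing measured here explains this difference. Still open, on these data alone, is whether an amine or a carboxylic acid on this aromatic ring, or a longer chain carrying it, could bring the number near that of compound 1 (60 nM).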